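The compounds below may be only part of what the source reports. "The series", "measured", "known", "first", "only" and "open" are said of these compounds alone.

Compound 1 `CC1=C2CC(C)(C)/C=C/C/C(C)=C\C3=C[C@H](C)C[C@]3(O2)C1=O`: 26000 nM
Compound 2 `CC1=C2CC(C)(C)[C@@H]3C=C(OC3)/C(C)=C\C3=C[C@H](C)C[C@]3(O2)C1=O`: 26000 nM

Both values come from an ADME assay on HepG2 cells (Homo sapiens) for cytotoxicity, read by CellTiter-Glo, with a stated time of 72 h; on this read-out lower numbers stand for an effect already at smaller amounts and higher numbers for an effect only at larger amounts of compound. Compound 1 stands level with compound 2 on these numbers, so neither is set apart from the other.

Compound 3 `CC(=O)O[C@H]1/C=C/C(C)(C)CC2=C(C)C(=O)[C@]3(C[C@@H](C)C=C3/C=C\1C)O2` keeps the core of compound 1 and changes it in one place: acetoxy in place of hydrogen on a saturated ring carbon. An acetoxy group takes the place of a hydrogen on a saturated ring carbon, next to the ring atom that bears a methyl group. Within the data shown here, no measured pair shows this change on its own, so the data offer no direct guide. Compound 2 has a different structure from compound 1, yet compound 2 still gives 26000 nM. In this assay, no step beyond the scatter is therefore expected, and neither direction is favoured. The expected change is a 1.2-fold lower number from compound 1 to compound 3 (0.07 log units; within the scatter). For compound 3 the estimated value is 22000 nM, with an expected range of 9000 nM to 50000 nM.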

Compound 3, half-maximal effective concentration: 26000 nM
For compound 3 the middle estimate is 1.2-fold (0.07 log units) below the measured one; the measured number falls inside the stated range.
By their numbers in this assay, from the lowest: compounds 1, 2 and 3 (each within the scatter of the next).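

In this assay there is no change at the digits printed from compound 1 to compound 3 (within the scatter) when acetoxy takes the place of hydrogen on a saturated ring carbon, next to the ring atom that bears a methyl group. Among these compounds, this is the first measured substitution at this position, and it shows that this ring carbon can carry acetoxy without a step beyond the scatter on this read-out. No available measurement explains this result.

A single group at this carbon cannot show whether the absence of a step in this assay is particular to acetoxy or would extend to other groups. A hydroxyl group, an amine or a carboxylic acid at the same carbon, or acetoxy with the opposite spatial arrangement there, could behave differently.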